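The compounds below may be only part of what the source reports. "The series", "measured", "known", "first", "only" and "open" are said of these compounds alone.

Series notes. In an assay on microsomes from liver for inhibition of 3-hydroxy-3-methylglutaryl-coenzyme A reductase (Rattus norvegicus) (a higher number here means a weaker inhibitor, a lower number a stronger inhibitor), compound 1 `CC(C)c1c(C(=O)N(C)Cc2cccc(F)c2)nn(-c2ccc(F)cc2)c1CC[C@@H](O)C[C@@H](O)CC(=O)O` gives 4.1 nM, compound 2 `CC(C)c1c(C(=O)N2CCC[C@H](N3CCC4C=CC=CC4C3)C2)nn(-c2ccc(F)cc2)c1CC[C@@H](O)C[C@@H](O)CC(=O)O` gives 10 nM, and compound 3 `COc1ccc(CNC(=O)c2nn(-c3ccc(F)cc3)c(OC[C@@H](O)C[C@@H](O)CC(=O)O)c2C(C)C)cc1` gives 12 nM. Compound 3 carries the highest of the three numbers; its value and that of compound 2 lie within the usual scatter of each other, whereas compound 1 gives a number that stands beyond the scatter below that of compound 3. Compound 4 `CC(C)c1c(C(=O)N(C)Cc2ccc(F)c(F)c2)nn(-c2ccc(F)cc2)c1OC[C@@H](O)C[C@@H](O)CC(=O)O` is not yet measured and differs from compound 3 in one place: (3,4-difluorobenzyl)(methyl)amino in place of (4-methoxybenzyl)amino on a carbonyl carbon. Among the compounds with values here, no step between measured compounds isolates this change, so the expectation rests on compound 1, the closest in build at the amide, which gives 4.1 nM. A modest step toward a lower number, near the edge of the scatter, is expected a 2.0-fold lower number from compound 3 to compound 4 (0.30 log units; within the scatter). For compound 4 in this assay the estimate is 6 nM, with a range from 2.5 nM to 15 nM.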

Compound 4, half-maximal inhibitory concentration: 5.7 nM
For compound 4 the middle estimate is 1.1-fold (0.02 log units) above the measured one, and the stated range covers the measured number.
By their numbers in this assay, from the lowest: compounds 1, 4, 2 and 3 (each within the scatter of the next, the first and the last beyond it).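

Within the data shown here, on a carbonyl carbon, (3,4-difluorobenzyl)(methyl)amino in place of (4-methoxybenzyl)amino gives in this assay a 2.1-fold lower number from compound 3 to compound 4 (0.32 log units; beyond the scatter), the only single-place step so far, and it shows that this position responds to a change of amide substituent. The swap removes the amide hydrogen and the methoxy group and adds two fluorines together, so the step cannot be assigned to any one of these. No measurement on hand accounts for the step. Still open, on these data alone, is what (3,4-difluorobenzyl)amino, without the methyl on nitrogen, or (4-methoxybenzyl)(methyl)amino would give, which would separate those parts.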